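Fluoro in place of methoxy on an aromatic carbon

A few compounds are considered here, and "the series" means these few. Any claim that something is new, unique, unknown or untested is made for them only; others in the source may bear on it.

In a functional assay on HCT-116 cells (Homo sapiens) for cytotoxicity, read by MTT assay, with a stated time of 72 h (on this read-out lower numbers stand for stronger inhibition and higher numbers for weaker inhibition), compound 1 (`O=S(=O)(c1ccccc1)c1nc2ccccc2nc1N1CCCC1`) gives 24200 nM as a measured number. Compound 2 (`Cc1ccc(S(=O)(=O)c2nc3ccccc3nc2N2CCCC2)cc1`) reads > 50000 nM as a limit. Compound 3 (`COc1ccc(S(=O)(=O)c2nc3ccccc3nc2N2CCCC2)cc1`) likewise reads > 50000 nM as a limit and has no number of its own. Compound 4 (`O=S(=O)(c1ccc(F)cc1)c1nc2ccccc2nc1N1CCCC1`) differs from it as follows: fluoro in place of methoxy on an aromatic carbon (fluoro in place of methoxy on an aromatic carbon, para to a large group). For the measured compounds named here, two measured steps bear on this change: an at least 2.0-fold higher number from compound 1 to compound 2 (0.31 log units; beyond the scatter) and an at least 2.0-fold higher number from compound 1 to compound 3 (0.31 log units; beyond the scatter) for the two groups entering in place of hydrogen. Both end at the limit of > 50000 nM in this assay, at which 2 of the 3 values shown sit, and give only a minimum size. Going by the values given here, no measured step involves fluoro. Compound 1, with hydrogen on that carbon, gives 24200 nM as its number, and compound 4 is expected to lie near this number. The expected change is an at least 1.6-fold lower number from compound 3 to compound 4 (0.22 log units; that floor lies within the scatter) toward a lower number, though a limit reading remains possible. For compound 4 the estimate is 30000 nM with an expected range of 14000 nM to 60000 nM in this assay overall.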

Compound 4, half-maximal inhibitory concentration: 20600 nM
The estimate for compound 4 lay 1.5-fold (0.16 log units) above the measured number; measured number inside the range.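

Fluoro on this carbon, para to a large group, gives a readable number where methoxy and methyl did not: replacing methoxy gives an at least 2.4-fold lower number from compound 3 to compound 4 (0.38 log units; beyond the scatter), and replacing methyl gives an at least 2.4-fold lower number from compound 2 to compound 4 (0.38 log units; beyond the scatter). Against hydrogen, fluoro gives a 1.2-fold lower number from compound 1 to compound 4 (0.07 log units; within the scatter), so this assay does not separate these two groups here. The first two steps are minimum sizes only, because compounds 2 and 3 stand at a limit: the limit of > 50000 nM in this assay, at which 2 of the 4 values shown sit.

Those limits leave methyl and methoxy unranked against each other. From the compounds shown here alone, how chloro, an amine or a carboxylic acid on this carbon would read remains open.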